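This account rests on a few compounds, and the source may have more. Where it says the series, first, only, none or still open, it means among the compounds named here.

Going by the values given here, compound 2 `COc1ccc2c(OCC[C@@H]3NC(=O)N(C)CCCC/C=C\[C@@H]4C[C@@]4(C(=O)NS(=O)(=O)C4(F)CC4)NC3=O)cc(-c3nc(C(C)C)cs3)nc2c1Cl` gives 51400 nM in an ADME assay on cells (Homo sapiens) for activation (on this read-out higher numbers stand for lower toxicity in this test and lower numbers for higher toxicity in this test), the lower of two numbers so far; compound 1 `COc1ccc2c(OCC[C@@H]3NC(=O)N(C)CCCC/C=C\[C@@H]4C[C@@]4(C(=O)NS(=O)(=O)C4(C)CC4)NC3=O)cc(-c3nc(C(C)C)cs3)nc2c1F` gives 57100 nM in this assay, and the gap between them lies within the scatter. Compound 3 `C#CC1(S(=O)(=O)NC(=O)[C@@]23C[C@H]2/C=C\CCCCN(C)C(=O)N[C@@H](CCOc2cc(-c4nc(C(C)C)cs4)nc4c(Cl)c(OC)ccc24)C(=O)N3)CC1` differs from compound 2 by ethynyl in place of fluoro on a saturated ring carbon. Among the compounds with values here, no measured step covers this change, and the two known values give no sign of a trend. The step of a 1.0-fold lower number from compound 2 to compound 3 (0.01 log units; within the scatter) is therefore expected to stay within the scatter, with no clear direction. For compound 3 the estimate in this assay is 50000 nM, within a range from 25000 nM to 100000 nM.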

Compound 3, half-maximal cytotoxic concentration: 26300 nM
The estimate for compound 3 lay 1.9-fold (0.28 log units) above the measured number; the range from low to high includes it.
By their numbers in this assay, from the lowest: compounds 3, 2 and 1 (each within the scatter of the next, the first and the last beyond it).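

In this assay, 1-fluorocyclopropyl to 1-ethynylcyclopropyl gives a 2.0-fold lower number from compound 2 to compound 3 (0.29 log units; within the scatter) and so stays within the scatter. Going by these compounds alone, this is the first one-place step, and it shows that on this saturated ring carbon, fluoro can give way to ethynyl without a step beyond the scatter. No measurement on hand offers an explanation for this step.

Still open, going by these compounds, is how an amine, a carboxylic acid or a longer chain on this ring carbon would read out in this assay. A single step also sets no trend for this position.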